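This account rests on a few compounds, and the source may have more. Where it says the series, first, only, none or still open, it means among the compounds named here.

Of the compounds shown here, three that share one core have been tested in an assay on HEK293 cells for positive allosteric modulation of metabotropic glutamate receptor 2 (Rattus norvegicus), read by thallium flux, with a stated time of 2.5 min; a higher number here means a larger maximal response, a lower number a smaller maximal response. Compound 1, `Cc1c(OCCCCOc2ccc(C(=O)C(C)C)c(O)c2C)cccc1C(=O)O`, gives 66.9% in this assay. Compound 2, `CCCC(=O)c1ccc(OCCCCOc2ccc(C(=O)O)cc2C)c(C)c1O`, gives 79.3%, and compound 3, `Cc1c(OCCCCOc2ccccc2C(=O)O)ccc(C(=O)CC(C)C)c1C`, gives 76.2%. The number for compound 1 is the lowest of the three, but the two neighbours are not alike in distance: the gap to compound 3 lies within the usual scatter of this kind of measurement, while the gap to compound 2 lies beyond it.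

Compound 4, `CC(=O)c1ccc(OCCCCOc2cccc(C(=O)O)c2C)c(C)c1O`, has not yet been measured. It differs from compound 1 in one place: methyl in place of isopropyl on a carbonyl carbon. Within the data shown here, no pair of measured compounds differs in exactly this way, so there is no measured step of this kind to lean on. Among compounds 1, 2 and 3 the group attached to the carbonyl carbon already varies, and the three numbers do not line up with that variation in any clear way. For that reason no step beyond the scatter is expected from compound 1 to compound 4, and the expected step is a number 3.1 percentage points higher from compound 1 to compound 4 (within the scatter). Compound 4 is estimated to give 70% in this assay, with a likely range from 55% to 85%.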

Compound 4, largest response reached (reported as percent of maximum), in percent of the reference or control that the assay uses: 79.2%
For compound 4 the middle estimate is 9.2 percentage points below the measured one, and the stated range covers the measured number.
By their numbers in this assay, from the lowest: compounds 1, 3, 4 and 2 (each within the scatter of the next, the first and the last beyond it).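

In this assay, among these compounds, the pair of compound 1 and compound 4 gives the first measured step that comes from a single change, methyl in place of isopropyl on a carbonyl carbon: a number 12.3 percentage points higher from compound 1 to compound 4 (beyond the scatter). The earlier compounds shown here differ from one another in more than one place, and none of their numbers could be tied to the group on this carbonyl carbon alone; this pair shows that exchanging that group, with the rest of the molecule unchanged, can move the maximal response beyond the usual scatter. Nothing available explains why this exchange raises the number.

This position therefore rests on a single pair, which leaves open whether the response follows the size of the group on the carbonyl carbon or whether the step belongs to these two groups alone. An ethyl or a cyclopropyl group at the same place, with the rest of compound 1 kept, would show whether the number changes gradually across such groups or whether a ring there behaves differently from an open chain.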